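Will compound 4 keep the long life of compound 3?

The compounds below may be only part of what the source reports. "The series", "measured", "known", "first", "only" and "open" are said of these compounds alone.

In an ADME assay on the whole organism (serum) with Homo sapiens as the target (a higher number here means that the compound lasts longer, a lower number that the compound disappears faster), compound 1 `Cc1cn(C2CC(N=[N+]=[N-])C(COC(=O)OCCCCCCCCO)O2)c(=O)[nH]c1=O` gives 0.0333 h and compound 2 `Cc1cn(C2CC(N=[N+]=[N-])C(COC(=O)OCCCC(=O)OC(C)(C)C)O2)c(=O)[nH]c1=O` gives 0.267 h. Compound 3 `Cc1cn(C2CC(N=[N+]=[N-])C(COC(=O)NCCCC(=O)O)O2)c(=O)[nH]c1=O` stands at > 48 h, which is a limit of the assay and not a number. On these data alone, it is the longest-lasting of the three, but its true half-life remains unknown.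

Compound 4 `Cc1cn(C2CC(N=[N+]=[N-])C(COC(=O)OCCCN)O2)c(=O)[nH]c1=O` places 3-aminopropoxy in place of (3-carboxypropyl)amino on a carbonyl carbon. The nearest guide is the large step of an at least 1400-fold higher number from compound 1 to compound 3 (3.15 log units; beyond the scatter), which replaced (8-hydroxyoctyl)oxy with (3-carboxypropyl)amino on that same carbonyl carbon. The change to compound 4 runs the opposite way, restoring an oxy group there. The modest step of an 8.0-fold higher number from compound 1 to compound 2 (0.90 log units; beyond the scatter) shows how far two oxy-linked chains differed, and both half-lives stayed short.

A large fall in this assay is therefore expected, estimated as an at least 240-fold lower number from compound 3 to compound 4 (2.38 log units; beyond the scatter). Compound 4 is expected to show a half-life of about 0.2 h, with an estimated range from 0.03 h to 1.5 h.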

Compound 4, half-life: 0.133 h
The estimate for compound 4 lay 1.5-fold (0.18 log units) above the measured number; measured number inside the range.
By their numbers in this assay, from the lowest: compound 1; then compounds 4 and 2 (each within the scatter of the next). At a limit, above all of these: compound 3.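

Compound 4 shows that the long life in this assay does not survive when 3-aminopropoxy replaces (3-carboxypropyl)amino on this carbonyl carbon (an at least 360-fold lower number from compound 3 to compound 4 (2.55 log units; beyond the scatter)). A chain with an amino end joins the other two oxy-linked compounds at short half-lives: the gap to the tert-butoxycarbonyl end stays within the scatter (a 2.0-fold lower number from compound 2 to compound 4 (0.30 log units; within the scatter)), and the gap to the 5-hydroxypentyl end is modest (a 4.0-fold higher number from compound 1 to compound 4 (0.60 log units; beyond the scatter)). Compound 3 remains a limit of the assay and not a number: the limit of > 48 h in this assay, at which 1 of the 4 values shown sits.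

The change to compound 4 alters the linking atom, the chain length and the chain end together, so the compounds shown cannot say which of these accounts for the drop. An amino-linked chain ending in an amine, or an oxy-linked chain ending in a carboxylic acid, would pull these apart.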